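Swapping an ethyl for a methoxy on the diacylhydrazine

A few compounds are considered here, and "the series" means these few. Any claim that something is new, unique, unknown or untested is made for them only; others in the source may bear on it.

Compound 1 `Cc1ccccc1C(=O)N(NC(=O)c1ccccc1)C(C)(C)C`: 224 nM
Compound 2 `CCc1ccccc1C(=O)N(NC(=O)c1ccccc1)C(C)(C)C`: 589 nM

Of the compounds shown here, two have been measured in an assay on cells for agonist activity at ecdysone receptor (Bombyx mori), read by a luciferase reporter, with a stated time of 24 h; on this read-out higher numbers stand for an effect only at larger amounts of compound and lower numbers for an effect already at smaller amounts. Compound 1 `Cc1ccccc1C(=O)N(NC(=O)c1ccccc1)C(C)(C)C` gives 224 nM, and compound 2 `CCc1ccccc1C(=O)N(NC(=O)c1ccccc1)C(C)(C)C` gives 589 nM. For the measured compounds named here, the only step between them, a 2.6-fold higher number from compound 1 to compound 2 (0.42 log units; beyond the scatter), lies beyond the scatter, so compound 2 stands with the higher of the two numbers.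

Compound 3 `COc1ccccc1C(=O)N(NC(=O)c1ccccc1)C(C)(C)C` has not been measured. It differs from compound 2 by methoxy in place of ethyl on an aromatic carbon; put one bond further out, a 2-ethylphenyl becomes a 2-methoxyphenyl. Going by the values given here, only the step from compound 1 to compound 2 bears on this change, and it touches the same position: there, lengthening methyl to ethyl raised the number. The methoxy that enters has the same count of heavy atoms as the ethyl that leaves, so no large move is expected. An estimate for compound 3 in this assay is therefore 400 nM, with a range from 150 nM to 1200 nM, meaning an expected step of a 1.5-fold lower number from compound 2 to compound 3 (0.17 log units; within the scatter), which is within the scatter.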

Compound 3, half-maximal effective concentration: 525 nM
Estimate against measurement, compound 3: 1.3-fold (0.12 log units) below, and the stated range covers the measured number.
By their numbers in this assay, from the lowest: compound 1; then compounds 3 and 2 (each within the scatter of the next).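

At this position on the aromatic ring, in this assay, methoxy and ethyl cannot be told apart (with a 1.1-fold lower number from compound 2 to compound 3 (0.05 log units; within the scatter)), even though the methoxy brings a hydrogen-bond acceptor and the ethyl brings none. The earlier pair showed only that ethyl read differently from methyl, so it could not say whether other groups with the same count of heavy atoms as ethyl would read like it; here one such group does. Compound 1 also keeps the lowest number of the three, since the methyl-to-methoxy change (with a 2.3-fold higher number from compound 1 to compound 3 (0.37 log units; beyond the scatter)) lies beyond the scatter, as does the methyl-to-ethyl step, and neither compound 2 nor compound 3 goes against this order. No measurement at hand accounts for these numbers.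

The compounds shown leave open how a hydroxyl, an amine or a longer chain such as propyl or ethoxy would read at this same place, and so whether the number keeps moving as the group grows past two heavy atoms. They also leave open whether methoxy and ethyl would stay this close elsewhere on the shared core.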